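A thiophene in place of a bromophenyl group

This account rests on a few compounds, and the source may have more. Where it says the series, first, only, none or still open, it means among the compounds named here.

Compound 1 `CC(=O)O[C@@H]1C[C@@H](OC(=O)c2ccccc2)/C(C)=C/[C@H]2[C@@H](OC(=O)c3ccccc3)[C@@H](C)[C@H](OC(C)=O)[C@]2(OC(C)=O)[C@H](O)[C@](C)(O)/C=C/C1(C)C`: 93300 nM
Compound 2 `CC(=O)O[C@@H]1C[C@@H](OC(=O)c2ccccc2)/C(C)=C/[C@H]2[C@@H](OC(=O)c3ccccc3)[C@@H](C)[C@H](OC(=O)c3ccc(Br)cc3)[C@]2(OC(C)=O)[C@H](O)[C@](C)(O)/C=C/C1(C)C`: 81300 nM

Both compounds were tested in a functional assay on HepG2 cells (Homo sapiens) for inhibition, read by MTT assay, with a stated time of 48 h; on this read-out lower numbers stand for stronger inhibition and higher numbers for weaker inhibition. For the measured compounds named here, only two numbers exist so far, and compound 2 at 81300 nM stands within the usual scatter of compound 1 at 93300 nM. On these data, the two cannot be told apart.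

The next compound is compound 3 `CC(=O)O[C@@H]1C[C@@H](OC(=O)c2ccccc2)/C(C)=C/[C@H]2[C@@H](OC(=O)c3ccccc3)[C@@H](C)[C@H](OC(=O)c3cccs3)[C@]2(OC(C)=O)[C@H](O)[C@](C)(O)/C=C/C1(C)C`, which carries thiophen-2-yl in place of 4-bromophenyl on a carbonyl carbon. The rest of the structure stays the same.

Going by the values given here, one measured step bears on this change, since it also exchanged the group on a carbonyl carbon. That step, 4-bromophenyl in place of methyl, is a 1.1-fold lower number from compound 1 to compound 2 (0.06 log units; within the scatter). Among the compounds with values here, this is thin evidence: it is a single pair, and no compound with a thiophen-2-yl group has a measured value yet. Within the data shown here, still, with a 1.1-fold lower number from compound 1 to compound 2 (0.06 log units; within the scatter) as the only guide, no change beyond the scatter is expected in this assay, and no direction can be favoured with confidence.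

The estimated step is a 1.0-fold higher number from compound 2 to compound 3 (0.02 log units; within the scatter). For compound 3 the expected value is 85000 nM, with an estimated range of 45000 nM to 140000 nM.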

Compound 3, half-maximal inhibitory concentration: > 150000 nM
Compound 3 gave a limit, no number; the forecaster's own chance of this, stated with the estimate: 15%; at least 1.7-fold (0.24 log units) between middle value and limit.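

In this assay compound 3 gives > 150000 nM, which is a limit of the assay and not a number. Placing thiophen-2-yl on this carbonyl carbon gives an at least 1.8-fold higher number from compound 2 to compound 3 (0.26 log units; that floor lies within the scatter), while the same group compared with the original methyl gives an at least 1.6-fold higher number from compound 1 to compound 3 (0.20 log units; that floor lies within the scatter). Methyl and 4-bromophenyl could not be told apart at this position, and compound 3 is the first compound here that might differ from the others, although both floors stay within the scatter and the true size of the change remains unknown because its result is a limit: the limit of > 150000 nM in this assay, at which 1 of the 3 values shown sits.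

On these data alone, it remains open whether the result of compound 3 depends on the sulfur, on the five-membered ring or on the loss of the bromine, and a plain phenyl or a furan-2-yl group on this carbonyl carbon would help to separate these possibilities. The compounds shown also leave open how an amine or a longer chain in this place would read, and whether any group here can bring the number clearly lower than that of compound 2.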